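A Fluorophenyl Swap on the Triazole Nitrogen

A few compounds are considered here, and "the series" means these few. Any claim that something is new, unique, unknown or untested is made for them only; others in the source may bear on it.

Of the compounds shown here, two have so far been measured in a functional assay on SGC-7901 cells (Homo sapiens) for antiproliferative activity, read by MTT assay, with a stated time of 24 h; a lower number here means a stronger inhibitor, a higher number a weaker inhibitor. Compound 1 `O=c1[nH]cc(S(=O)(=O)Nc2ccccc2-c2cn(-c3ccc(Cl)cc3)nn2)c(=O)[nH]1` gives 2700 nM. Compound 2 `Cc1ccccc1-n1cc(-c2ccc(NS(=O)(=O)c3c[nH]c(=O)[nH]c3=O)cc2)nn1` gives 13600 nM, the highest of the two numbers, and its gap to compound 1 lies beyond the usual scatter of this kind of measurement. Compound 3 `O=c1[nH]cc(S(=O)(=O)Nc2ccc(-c3cn(-c4cccc(F)c4)nn3)cc2)c(=O)[nH]1` is the next compound to be tested, and it differs from compound 2 in one place: 3-fluorophenyl in place of 2-methylphenyl on an aromatic nitrogen. For the measured compounds named here, no pair of measured compounds differs by this change alone, so the size of the step cannot be read from any measured pair and must be judged from compound 2 and compound 1 together. Compound 3 is expected in this assay at 8000 nM, within a range of 3000 nM to 20000 nM. The estimated step of a 1.7-fold lower number from compound 2 to compound 3 (0.23 log units; within the scatter) is expected to be a modest move toward a lower number, possibly not beyond the scatter.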

Compound 3, half-maximal inhibitory concentration: > 20000 nM
Compound 3 ended at the assay's limit (the forecaster's own chance of this, stated with the estimate: 5%); at least 2.5-fold (0.39 log units) between middle value and limit.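

In this assay, compound 3 carries a limit of the assay and not a number: the limit of > 20000 nM in this assay, at which 1 of the 3 values shown sits.

For the compounds shown here, this gives the first measured pair that differs at this aromatic nitrogen alone, and 3-fluorophenyl in place of 2-methylphenyl amounts to an at least 1.4-fold higher number from compound 2 to compound 3 (0.16 log units; that floor lies within the scatter). The true size of the step cannot be read, but the swap did not bring the number down, so a fluorine-bearing phenyl on this nitrogen offers no gain over the methyl-bearing one in compound 2.

The compounds shown leave open how this nitrogen would respond to an amine or a carboxylic acid on the phenyl ring, or to a plain alkyl chain in place of that ring. Compound 1 differs from compound 3 in more than one place, so it cannot settle this.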